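Swapping the side ring back: from pyridazine to chloropyridine

This account rests on a few compounds, and the source may have more. Where it says the series, first, only, none or still open, it means among the compounds named here.

Measured compounds:
- Compound 1, `C[C@@H](Oc1cc2oc(=O)n(CCC(=O)O)c2cc1Cl)c1ccc(F)cn1`: 25.1 nM
- Compound 2, `Cc1ccc([C@@H](C)Oc2cc3oc(=O)n(CCC(=O)O)c3cc2Cl)nc1`: 6.31 nM
- Compound 3, `C[C@@H](Oc1cc2oc(=O)n(CCC(=O)O)c2cc1Cl)c1cccnn1`: 631 nM

All three share one core and differ only in the aromatic ring hanging from the saturated chain carbon that is bound to an oxygen on the aromatic ring. In an assay on HEK293 cells for inhibition of kynurenine 3-monooxygenase (Homo sapiens), read by LC-MS, with a stated time of 20 h (on this read-out lower numbers stand for stronger inhibition and higher numbers for weaker inhibition), compound 3 gives the highest number of the three, and so the weakest inhibition. Its nearest neighbour is compound 1, its furthest compound 2.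

Compound 4, `C[C@@H](Oc1cc2oc(=O)n(CCC(=O)O)c2cc1Cl)c1ccc(Cl)cn1`, differs from compound 3 by 5-chloropyridin-2-yl in place of pyridazin-3-yl on a saturated chain carbon bound to an oxygen on an aromatic ring and a saturated chain carbon. Within the data shown here, two measured steps bear on this change, both run in the opposite direction: a 25-fold higher number from compound 1 to compound 3 (1.40 log units; beyond the scatter) and a 100-fold higher number from compound 2 to compound 3 (2.00 log units; beyond the scatter). In both cases, putting a pyridazin-3-yl ring in place of a 5-substituted pyridin-2-yl ring gave a much weaker inhibitor. Compound 4 restores a 5-substituted pyridin-2-yl ring, so a large drop in number in this assay is expected, of roughly the size seen in those steps.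

Compound 4 is therefore expected to give about 10 nM in this assay, somewhere between 3 nM and 30 nM, which would mean an estimated step of a 63-fold lower number from compound 3 to compound 4 (1.80 log units; beyond the scatter).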

Compound 4, half-maximal inhibitory concentration: 100 nM
Compound 4: the middle estimate sits 10-fold (1.00 log units) below what was measured; measured number outside the range, above it.
By their numbers in this assay, from the lowest: compound 2; then compound 1; then compound 4; then compound 3.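

In this assay, among these compounds, returning to a 5-substituted pyridin-2-yl ring gives only a 6.3-fold lower number from compound 3 to compound 4 (0.80 log units; beyond the scatter) and so recovers far less than the earlier steps suggested, which shows that the ring type alone does not set the strength of inhibition at this position. Among the compounds shown here, the single group on that ring matters just as much: chloro in place of fluoro gives a 4.0-fold higher number from compound 1 to compound 4 (0.60 log units; beyond the scatter) and chloro in place of methyl gives a 16-fold higher number from compound 2 to compound 4 (1.20 log units; beyond the scatter) in this set, leaving compound 4 the weakest of the three pyridine compounds, even though chloro, fluoro and methyl differ only at this one place. No measurement shown here explains why these three groups fall in this order.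

For the compounds shown here, with only three groups on the pyridine ring, it remains unclear whether the result for methyl reflects something more general or is specific to that group. A methoxy, an ethyl or a nitrile in place of the chloro on the same ring would show whether other groups fall closer to compound 2 or to compound 4.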